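This account rests on a few compounds, and the source may have more. Where it says the series, first, only, none or still open, it means among the compounds named here.

In a functional assay on the whole organism with Mus musculus as the target (on this read-out lower numbers stand for an effect already at smaller amounts and higher numbers for an effect only at larger amounts of compound), compound 1 `CCN(C)C(=O)/C=C1\CCc2c(F)cc(F)cc21` gives 56 mg/kg. Compound 2 `Cc1cccc2c1CC/C2=C\C(=O)NC1CC1` gives 40 mg/kg, so compound 2 stands level with compound 1, the two values lying within the usual scatter of each other. Compound 3 `O=C(/C=C1\CCc2ccccc21)NC1CC1` differs from compound 2 at one place, with hydrogen in place of methyl on an aromatic carbon. Going by the values given here, no measured pair shows this change, so no step beyond the scatter is expected in this assay. The estimated change is a 1.1-fold higher number from compound 2 to compound 3 (0.05 log units; within the scatter). For compound 3 the expected dose is 45 mg/kg, with an estimated range from 18 mg/kg to 110 mg/kg.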

Compound 3, dose for half-maximal effect: 150 mg/kg
Compound 3: middle estimate off by 3.3-fold (0.52 log units), on the low side; the whole stated range lies below it.
By their numbers in this assay, from the lowest: compounds 2 and 1 (each within the scatter of the next); then compound 3.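

In this assay, going by these compounds alone, this change brings a 3.8-fold higher number from compound 2 to compound 3 (0.57 log units; beyond the scatter) and is the first single-place step that can be read on this series. It shows that this aromatic carbon, ortho to a fused ring and meta to a fused ring, is not indifferent to what it carries: the loss of one methyl carbon is enough to move the number beyond the scatter. Nothing available explains the step.

On these data alone, whether ethyl, methoxy or chlorine on this carbon would give a number like that of compound 2 stays open.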